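This account rests on a few compounds, and the source may have more. Where it says the series, first, only, none or still open, it means among the compounds named here.

Compound 1: `CC[C@H](C)[C@@H](CN(C(=O)[C@@H]1C[C@H]1c1ccccc1)c1ccc(-c2ccccc2)cc1)NC(C)=O` — 5.8 nM
Compound 2: `N[C@H](CN(C(=O)[C@@H]1C[C@H]1c1ccccc1)c1ccc(-c2ccccc2)cc1)C1CCCCC1` — 0.66 nM
Compound 3: `CC[C@H](C)[C@H](N)CN(C(=O)[C@@H]1C[C@H]1c1ccc(F)cc1)c1ccc(-c2ccccc2)cc1` — 600 nM

Of the compounds shown here, three sharing one core have been measured in a functional assay for agonist activity at G protein-coupled receptor 88 (Homo sapiens), read by HTRF and cAMP accumulation; a higher number here means that more compound is needed for the effect, a lower number that less compound is needed. Compound 1 gives 5.8 nM, compound 2 gives 0.66 nM, and compound 3 gives 600 nM, the highest number of the three, far beyond the scatter from either neighbour. Among the compounds with values here, the only step between two measured compounds that differ in one place is an 8.8-fold lower number from compound 1 to compound 2 (0.94 log units; beyond the scatter), and it lies on the chain bound to the amide-type nitrogen.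

Compound 4 `CC[C@H](C)[C@H](N)CN(C(=O)[C@@H]1C[C@H]1c1cncnc1)c1ccc(-c2ccccc2)cc1` is the next to be measured. It differs from compound 3 as follows: pyrimidin-5-yl in place of 4-fluorophenyl on a saturated ring carbon Cut one bond further out, the same change reads 2-(4-fluorophenyl)cyclopropyl to 2-(pyrimidin-5-yl)cyclopropyl. Within the data shown here, the step from compound 1 to compound 2 concerns a different part of the molecule and so does not bear on this change; no measured pair shows what exchanging the group on the three-membered ring does. The expectation for compound 4 is therefore anchored to compound 3 with a wide range in both directions. Compound 4 is expected to give 800 nM in this assay, between 200 nM and 3500 nM. That estimate means an expected step of a 1.3-fold higher number from compound 3 to compound 4 (0.12 log units; within the scatter).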

Compound 4, half-maximal effective concentration: 19000 nM
Beside the measured number, compound 4's estimate is 24-fold (1.38 log units) below it, outside the stated range (above it).
By their numbers in this assay, from the lowest: compound 2; then compound 1; then compound 3; then compound 4.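

Within the data shown here, this pair is the first measured exchange of the group on the three-membered ring, and in this assay it gives a 32-fold higher number from compound 3 to compound 4 (1.50 log units; beyond the scatter), a large step. The number therefore depends strongly on which aromatic ring stands on this saturated ring carbon: the carbon-only ring of 4-fluorophenyl, with 0 hydrogen-bond acceptors, gives way to pyrimidin-5-yl, with 2 hetero atoms and 2 hydrogen-bond acceptors, and far more compound is needed. Nothing measured here accounts for the size of this step.

As far as these compounds go, with a single pair at this position, it remains open whether plain phenyl, pyridin-3-yl or 4-chlorophenyl would give numbers closer to compound 3 or to compound 4. From the compounds shown here alone, it is also open whether the exchange would have the same effect alongside the amino(cyclohexyl)methyl group of compound 2.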